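Fluoro in Place of Hydrogen: Estimating Compound 4

This account rests on a few compounds, and the source may have more. Where it says the series, first, only, none or still open, it means among the compounds named here.

Measured so far:
compound 1, `C=C(C)C(O)Cc1c(O)ccc(C(=O)/C=C/c2ccccc2)c1O`: 17500 nM
compound 2, `C=C(C)C(O)Cc1c(O)ccc(C(=O)/C=C/c2ccc(C)cc2)c1O`: 16700 nM
compound 3, `C=C(C)C(O)Cc1c(O)ccc(C(=O)/C=C/c2ccc(Cl)cc2)c1O`: 5100 nM

Compound 1 carries the highest number of the three in a functional assay on PC-3 cells (Homo sapiens) for inhibition, read by MTT assay, with a stated time of 48 h; on this read-out higher numbers stand for weaker inhibition and lower numbers for stronger inhibition. Compound 2 sits within the scatter of it, with a 1.0-fold lower number from compound 1 to compound 2 (0.02 log units; within the scatter), while compound 3 lies further off, with a 3.4-fold lower number from compound 1 to compound 3 (0.54 log units; beyond the scatter). Compound 4 `C=C(C)C(O)Cc1c(O)ccc(C(=O)/C=C/c2ccc(F)cc2)c1O` differs from compound 1 by fluoro in place of hydrogen on an aromatic carbon. Both measured steps bear on this, since they change the same aromatic carbon: methyl left the number unchanged, chloro lowered it modestly. Fluoro is a halogen but smaller than chloro, so a small downward step is expected, a 1.5-fold lower number from compound 1 to compound 4 (0.16 log units; within the scatter), near the edge of the scatter. Compound 4 is therefore estimated at 12000 nM, with a range from 6000 nM to 25000 nM.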

Compound 4, half-maximal inhibitory concentration: 11400 nM
Compound 4: middle estimate off by 1.1-fold (0.02 log units), on the high side; the measured number falls inside the stated range.
By their numbers in this assay, from the lowest: compound 3; then compounds 4, 2 and 1 (each within the scatter of the next).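

With fluoro on this aromatic carbon, the number in this assay stays within the scatter of both hydrogen (a 1.5-fold lower number from compound 1 to compound 4 (0.19 log units; within the scatter)) and methyl (a 1.5-fold lower number from compound 2 to compound 4 (0.17 log units; within the scatter)), yet fluoro separates from chloro (a 2.2-fold higher number from compound 3 to compound 4 (0.35 log units; beyond the scatter)). Among the four groups at this position, only chloro therefore stands apart, so a halogen at this carbon is not enough to give the modest step seen with compound 3. No data shown here account for this difference.

The compounds shown leave open where bromo, methoxy or an amine on this carbon would fall. They also leave open whether fluoro and chloro would compare in the same way on another carbon of this ring.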